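The compounds below may be only part of what the source reports. "The series", "measured", "known", "first", "only" and "open" are said of these compounds alone.

Measured compounds and their values:
Compound 1, `CC1c2c(-c3ccncc3)c(-c3ccccc3C#N)nn2CC1(C)C`, in a functional assay on MCF7 cells (Homo sapiens) for cytotoxicity, with a stated time of 72 h (on this read-out higher numbers stand for weaker inhibition and lower numbers for stronger inhibition), gives > 100000 nM, which is a limit of the assay and not a number.
Compound 2, `Cc1cccc(-c2nn3c(c2-c2ccncc2)C(C)C(C)(C)C3)c1C#N`, in this assay gives 97000 nM.
Compound 3, `CC1(C)Cc2c(-c3ccncc3)c(-c3ccccn3)nn2C1`, in this assay gives > 100000 nM, which is again a limit of the assay and not a number.

Compound 2 differs from compound 1 by methyl in place of hydrogen on an aromatic carbon. The measured step is an at least 1.0-fold lower number from compound 1 to compound 2 (0.01 log units; that floor lies within the scatter), so the change left the read-out essentially where it was. Two of the three values sit at the limit of > 100000 nM in this assay, at which 2 of the 3 values shown sit, so within this small set nothing is resolved against the scatter.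

Compound 3 has a different core; the difference between the two cores is not broken down here. Compound 4, `Cc1cccc(-c2nn3c(c2-c2ccncc2)CC(C)(C)C3)n1`, is the next compound and differs from compound 3 by methyl in place of hydrogen on an aromatic carbon. Among the measured compounds shown here, this is the same kind of change as the one from compound 1 to compound 2, but not the same: in compound 2 the methyl sits on a six-membered aromatic ring of carbon only, ortho to a cyano group, whereas in compound 4 it sits on a six-membered aromatic ring with one nitrogen, next to the ring nitrogen.

For compound 4 the expected step is a number no higher from compound 3 to compound 4 (the limit leaves the size open), and this expectation rests on the earlier methyl step, because an at least 1.0-fold lower number from compound 1 to compound 2 (0.01 log units; that floor lies within the scatter) stayed within the scatter. Compound 4 is therefore estimated at 100000 nM, with a range from 50000 nM to 200000 nM.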

Compound 4, half-maximal inhibitory concentration: > 100000 nM
Compound 4 was reported as a limit (the forecaster's own chance of this, stated with the estimate: 60%); the middle value lies on the limit itself.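

Compound 3 and compound 4 both rest on a limit of the assay and not on a number, so no step between them can be read: the limit of > 100000 nM in this assay, at which 3 of the 4 values shown sit.

The compounds shown leave open how far the change from pyridin-2-yl to 6-methylpyridin-2-yl moves the read-out in this assay, and which changes to these structures would give a value clearly away from that limit.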